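Swapping an aryl on the triazole of a chalcone series

A few compounds are considered here, and "the series" means these few. Any claim that something is new, unique, unknown or untested is made for them only; others in the source may bear on it.

Three chalcone-type compounds were examined in a functional assay on RAW264.7 cells (Mus musculus) for inhibition, with a stated time of 4 days; on this read-out lower numbers stand for stronger inhibition and higher numbers for weaker inhibition. Compound 1, `COc1cc(/C=C/C(=O)c2cccc(-n3cc(-c4ccccc4C(F)(F)F)nn3)c2)ccc1O`, gives 5070 nM in this assay. Compound 2, `COc1cc(/C=C/C(=O)c2cccc(-n3cc(-c4cccc(Cl)c4)nn3)c2)ccc1O`, gives 14300 nM. Compound 3, `COc1ccc(/C=C/C(=O)c2cccc(-n3cc(-c4ccccc4C(F)(F)F)nn3)c2)cc1O`, gives 9120 nM. The difference between compound 1 and compound 2 is 3-chlorophenyl in place of 2-(trifluoromethyl)phenyl on an aromatic carbon, and that change produced a 2.8-fold higher number from compound 1 to compound 2 (0.45 log units; beyond the scatter). Compound 3 differs from compound 1 in a different way, namely (3-hydroxy-4-methoxyphenyl in place of 4-hydroxy-3-methoxyphenyl on a double-bonded chain carbon bound to a double-bonded chain carbon), with a 1.8-fold higher number from compound 1 to compound 3 (0.25 log units; within the scatter).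

Compound 4, `COc1ccc(/C=C/C(=O)c2cccc(-n3cc(-c4cccc(Cl)c4)nn3)c2)cc1O`, has not yet been measured. It is related to compound 3 by 3-chlorophenyl in place of 2-(trifluoromethyl)phenyl on an aromatic carbon, which is the same change as that from compound 1 to compound 2, made on the core of compound 3 rather than on the core of compound 1. The account of where the change sits reads the same in both cases. Because a 2.8-fold higher number from compound 1 to compound 2 (0.45 log units; beyond the scatter) weakened inhibition on the core of compound 1, the same kind of outcome is expected on the core of compound 3, the estimated step being a 2.7-fold higher number from compound 3 to compound 4 (0.44 log units; beyond the scatter). This rests on a single measured pair, so the expectation carries the uncertainty of one example. The estimated value for compound 4 in this assay is 25000 nM, with a likely range from 12000 nM to 55000 nM.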

Compound 4, half-maximal inhibitory concentration: 6610 nM
Beside the measured number, compound 4's estimate is 3.8-fold (0.58 log units) above it, outside the stated range (below it).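

Placing 3-chlorophenyl in place of 2-(trifluoromethyl)phenyl on the core of compound 3 gave a 1.4-fold lower number from compound 3 to compound 4 (0.14 log units; within the scatter), so the weakening seen on the core of compound 1 did not carry over: the same change on two cores in this assay, a 2.8-fold higher number (0.45 log units; beyond the scatter) from compound 1 to compound 2 and a 1.4-fold lower number (0.14 log units; within the scatter) from compound 3 to compound 4, 3.9-fold (0.59 log units) apart, beyond the scatter of two such steps. The exchange of 4-hydroxy-3-methoxyphenyl for 3-hydroxy-4-methoxyphenyl also behaved differently once the 3-chlorophenyl group was present, giving a 2.2-fold lower number from compound 2 to compound 4 (0.34 log units; beyond the scatter), and its two outcomes are likewise set apart: the same change on two cores in this assay, a 1.8-fold higher number (0.25 log units; within the scatter) from compound 1 to compound 3 and a 2.2-fold lower number (0.34 log units; beyond the scatter) from compound 2 to compound 4, 3.9-fold (0.59 log units) apart, beyond the scatter of two such steps. Among these four compounds, then, the result of either change depends on what stands at the other place, so a step measured on one core was a poor guide to the other, but each comparison rests on a single pair of steps, and the numbers do not say what lies behind the difference.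

As far as these compounds go, it remains open whether this dependence extends beyond these two aryl groups and two hydroxy-methoxy patterns, for instance to a plain phenyl or to a phenyl bearing a nitrile or a carboxylic acid. Also unsettled is whether a second hydroxyl or an amine on the other aryl group would shift the outcome of the same exchange.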